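From piperidin-4-yl to pyrimidin-2-yl on an aromatic nitrogen

The compounds below may be only part of what the source reports. "The series", "measured", "known", "first", "only" and "open" are said of these compounds alone.

Three compounds sharing one core were measured in a functional assay on HT-29 cells (Homo sapiens) for inhibition, read by luminescence and CellTiter-Glo, with a stated time of 24 h (a higher number here means that more compound is needed for the effect, a lower number that less compound is needed), and they differ only in the group on an aromatic nitrogen. With 4,4,4-trifluorobutyl, compound 1 `CN1C(=S)[C@@H](NC(=O)c2nc(Cc3ccccc3)n(CCCC(F)(F)F)n2)COc2ccccc21` gives 2380 nM. With cyclopentyl, compound 2 `CN1C(=S)[C@@H](NC(=O)c2nc(Cc3ccccc3)n(C3CCCC3)n2)COc2ccccc21` gives 3530 nM, and the difference between these two, a 1.5-fold higher number from compound 1 to compound 2 (0.17 log units; within the scatter), stays within the scatter. With piperidin-4-yl, compound 3 `CN1C(=S)[C@@H](NC(=O)c2nc(Cc3ccccc3)n(C3CCNCC3)n2)COc2ccccc21` gives 1000 nM, the lowest of the three numbers. It is separated from the other two by modest steps: a 2.4-fold lower number from compound 1 to compound 3 (0.38 log units; beyond the scatter) and a 3.5-fold lower number from compound 2 to compound 3 (0.55 log units; beyond the scatter).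

Compound 4 `CN1C(=S)[C@@H](NC(=O)c2nc(Cc3ccccc3)n(-c3ncccn3)n2)COc2ccccc21` carries pyrimidin-2-yl in place of piperidin-4-yl on an aromatic nitrogen. Within the data shown here, no measured compound has an aromatic ring at this place, so the evidence is indirect. Among the measured compounds shown here, compound 4 gives up the group seen only in compound 3, and the two measured compounds without it lie higher, as a 3.5-fold lower number from compound 2 to compound 3 (0.55 log units; beyond the scatter) shows in reverse. A modest upward move is therefore expected, and the estimated change is a 2.4-fold higher number from compound 3 to compound 4 (0.38 log units; beyond the scatter). The estimated value for compound 4 is 2400 nM, with an expected range from 800 nM to 7500 nM.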

Compound 4, half-maximal effective concentration: 3970 nM
Compound 4: middle estimate off by 1.7-fold (0.22 log units), on the low side, within the range that was stated.
By their numbers in this assay, from the lowest: compound 3; then compounds 1, 2 and 4 (each within the scatter of the next).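

Pyrimidin-2-yl, the first aromatic ring at this place, does not keep the lower number seen with piperidin-4-yl, as a 4.0-fold higher number from compound 3 to compound 4 (0.60 log units; beyond the scatter) shows. Instead it sits with the two non-aromatic groups: a 1.1-fold higher number from compound 2 to compound 4 (0.05 log units; within the scatter) and a 1.7-fold higher number from compound 1 to compound 4 (0.22 log units; within the scatter) both stay within the scatter, so a trifluorinated chain, a carbocycle and an aromatic ring with two ring nitrogens cannot be told apart here, and only compound 3 stands apart. Nothing measured accounts for this step.

The compounds shown leave open whether the ring nitrogen of piperidin-4-yl matters, which an N-acetylpiperidin-4-yl group or a tetrahydropyran-4-yl group with oxygen in that ring would test. They also leave open whether an open-chain amine such as 2-aminoethyl would give a similar number to compound 3.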